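A few compounds are considered here, and "the series" means these few. Any claim that something is new, unique, unknown or untested is made for them only; others in the source may bear on it.

Measured compounds and their values in a functional assay on the whole organism (strain Swiss albino) for inhibition, with Mus musculus as the target, in the formalin test, with a stated time of 30 min, at a dose of 100 mg/kg; on this read-out lower numbers stand for less inhibition and higher numbers for more inhibition at the one dose given (going by the name of the read-out):
- compound 1, `CCN1CCc2c(c(C)nn2C(=O)Nc2cc(C)ccc2C)C1`, gives 55.8%
- compound 2, `CCN1CCc2c(c(C)nn2C(=O)Nc2ccc(F)cc2F)C1`, gives 14.3%
- compound 3, `CCN1CCc2c(c(C)nn2C(=O)Nc2cccc(C(F)(F)F)c2)C1`, gives 23.1%

Among these three numbers compound 2 stands lowest. Its nearest neighbour is compound 3, whose value lies within the usual scatter of compound 2, so the two cannot be told apart. Its furthest neighbour is compound 1, whose value lies beyond the scatter, clearly higher.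

Compound 4, `CCN1CCc2c(c(C(C)(C)C)nn2C(=O)Nc2ccc(F)cc2F)C1`, has not yet been tested in this assay. It differs from compound 2 in a single place: tert-butyl in place of methyl on an aromatic carbon. Among the measured compounds shown here, no pair of measured compounds differs in this way, so the data offer no measured step that shows what this change does. The three aryl amides of this set vary only at the aryl part, and all of them share the methyl that compound 4 replaces.

With nothing to lean on, a step of modest size is expected, in either direction, and most likely not beyond the scatter. Compound 4 is estimated to give 20%, with a range from 5% to 45%. The expected step of a number 5.7 percentage points higher from compound 2 to compound 4 (within the scatter) is therefore small and uncertain in sign.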

Compound 4, a percentage reported as inhibition, in the whole organism at one dose (the size of the read-out at that dose, not a potency): 73.4%
Beside the measured number, compound 4's estimate is 53.4 percentage points below it, outside the stated range (above it).
By their numbers in this assay, from the lowest: compounds 2 and 3 (each within the scatter of the next); then compound 1; then compound 4.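

In this assay, among the compounds shown here, the carbon of the five-membered aromatic ring that bears methyl in the earlier compounds turns out to be a place where a single change counts: tert-butyl in place of methyl gives a number 59.1 percentage points higher from compound 2 to compound 4 (beyond the scatter). The earlier compounds shown here all keep that methyl and vary only at the aryl part, so they could say nothing about this carbon, and this step shows that the read-out responds to it at least as strongly as to anything seen at the aryl part. No measurement shown here bears on why the number rises.

Going by these compounds, whether tert-butyl brings the same gain alongside the aryl parts of compound 1 and compound 3 remains open, since the step rests on a single pair. Also open, on these data alone, is how ethyl, isopropyl or cyclopropyl on this carbon would compare with methyl and tert-butyl.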